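Swapping an Amide for Phenyl on a Piperazine

This account rests on a few compounds, and the source may have more. Where it says the series, first, only, none or still open, it means among the compounds named here.

Compound 1, `COc1ccc(-c2cnc3nc(N)nc(N4CCN(C(=O)COc5ccccc5)CC4)c3n2)cc1OC`, is the starting point of this step. For the measured compounds named here, in a functional assay on cells (T-cell, Homo sapiens) for inhibition (on this read-out lower numbers stand for stronger inhibition and higher numbers for weaker inhibition), compound 1 gives 4 nM, the only full number among the two values shown. Compound 2, `COc1ccc(-c2cnc3nc(N)nc(OC(C)C)c3n2)cc1`, is a simpler relative. In this assay compound 2 reports only a limit, > 10000 nM. That value is the limit of > 10000 nM in this assay, at which 1 of the 2 values shown sits. Going by the values given here, compound 2 differs from compound 1 in more than one place, so the two values show only that compound 1 is measurably active while compound 2 is not resolved by the assay.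

The compound that is not yet measured is compound 3, `COc1ccc(-c2cnc3nc(N)nc(N4CCN(c5ccccc5)CC4)c3n2)cc1OC`. It differs from compound 1 in a single spot: phenyl in place of (phenoxymethyl)carbonyl on an amine nitrogen in a ring. Among the compounds with values here, no measured pair of compounds differing in just one place is available, so the size of this step rests on expectation alone.

The step of a 3.0-fold higher number from compound 1 to compound 3 (0.48 log units; beyond the scatter) is expected to be small, toward weaker inhibition, close to the edge of the usual scatter. Compound 3 is therefore estimated at 12 nM, with a likely range from 3 nM to 50 nM.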

Compound 3, half-maximal inhibitory concentration: 400 nM
Compound 3: the middle estimate sits 33-fold (1.52 log units) below what was measured, and the stated range ends below it.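

The change brings a 100-fold higher number from compound 1 to compound 3 (2.00 log units; beyond the scatter), so in this assay the read-out depends strongly on what sits on this amine nitrogen in the ring. Both groups carry a six-membered aromatic ring of carbon only, so that ring alone is not enough to keep the number as low as in compound 1; what leaves with the change is the carbonyl, the ether oxygen and the short chain that holds the ring further from the nitrogen. Nothing measured here gives a reason for the size of this step.

All of those parts go in a single change, so the compounds shown cannot tell which of them carries the difference. A benzoyl group, which keeps the carbonyl but loses the ether oxygen, and a 2-phenoxyethyl group, which keeps the ether oxygen but loses the carbonyl, are the kinds of group that would pull these parts apart on the same nitrogen.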